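The source may report more compounds than this note shows. Statements on the series, on what has been measured and on what is new or still open speak of the compounds shown alone.

Of the compounds shown here, three have so far been measured in an assay on isolated protein for inhibition of cathepsin S (Homo sapiens); a lower number here means a stronger inhibitor, a higher number a weaker inhibitor. Compound 1 `CC(=O)N1CCc2c(c(-c3ccc(C(F)(F)F)cc3)nn2CC(O)CN2CCC(c3csc4cc(F)ccc34)CC2)C1` gives 290 nM, compound 2 `CS(=O)(=O)N1CCc2c(c(-c3ccc(C(F)(F)F)cc3)nn2CC(O)CN2CCC(c3csc4cc(F)ccc34)CC2)C1` gives 180 nM, and compound 3 `CCNC(=O)c1sc2cc(F)ccc2c1C1CCN(CCCn2nc(-c3ccc(C(F)(F)F)cc3)c3c2CCN(S(C)(=O)=O)C3)CC1` gives 37 nM. Compound 2 stands second highest of these three numbers: its nearest neighbour is compound 1, whose number is higher by a margin within the scatter, and the furthest is compound 3, whose number is lower by a margin beyond the scatter. Within the data shown here, the only step between compounds that differ in a single place is a 1.6-fold lower number from compound 1 to compound 2 (0.21 log units; within the scatter), which swaps the group on the ring nitrogen of the shared core.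

Compound 4 `CS(=O)(=O)N1CCc2c(c(-c3ccc(C(F)(F)F)cc3)nn2CC(O)CN2CCC(c3c[nH]c4ccncc34)CC2)C1` is not yet measured. It differs from compound 2 in one place: a group of 9 heavy atoms (7 carbon, 2 nitrogen; one five-membered aromatic ring with 1 hetero atom, one six-membered aromatic ring with 1 hetero atom) in place of a group of 10 heavy atoms (8 carbon, 1 fluorine, 1 sulfur; one five-membered aromatic ring with 1 hetero atom, one six-membered aromatic ring of carbon only), on a saturated ring carbon. Among the measured compounds shown here, no measured step changes this part of the molecule; the step of a 1.6-fold lower number from compound 1 to compound 2 (0.21 log units; within the scatter) touches another part, and compound 3 differs from compound 2 in several places at once, so its value shows nothing about this change alone. The expected step is therefore a 1.4-fold higher number from compound 2 to compound 4 (0.14 log units; within the scatter), small and uncertain in direction. Compound 4 is estimated at 250 nM in this assay, with a range from 70 nM to 900 nM.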

Compound 4, half-maximal inhibitory concentration: 58 nM
Estimate against measurement, compound 4: 4.3-fold (0.63 log units) above; the measured number lies below the stated range.
By their numbers in this assay, from the lowest: compounds 3 and 4 (each within the scatter of the next); then compounds 2 and 1 (each within the scatter of the next).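

This position on the saturated ring carbon responds to a change of group: in this assay, the swap gives a 3.1-fold lower number from compound 2 to compound 4 (0.49 log units; beyond the scatter), a modest step beyond the scatter, whereas the earlier change on the ring nitrogen, a 1.6-fold lower number from compound 1 to compound 2 (0.21 log units; within the scatter), stayed within it. For this pair, the 6-fluoro-1-benzothiophen-3-yl group, with its sulfur and fluorine, is not needed for the lower number, since the entering group carries neither atom and adds a hydrogen-bond donor. Nothing available explains why the number falls.

The step changes several features at once, so it cannot show whether the sulfur, the fluorine or the nitrogen in the six-membered ring matters most. A plain 1-benzothiophen-3-yl or an indol-3-yl group, with carbon only in its six-membered ring, would help separate these features.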